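Extending the Urea Arm of Compound 3

The source may hold more compounds than are shown below. What is called first, only, known or untested is meant among the compounds shown, and "the series" means these compounds.

Of the compounds shown here, three built on one shared core have been tested in a functional assay on Ehrlich cells (Mus musculus) for cytotoxicity, read by trypan blue exclusion, with a stated time of 2 h, tested at 50 ug/mL; on this read-out higher numbers stand for a stronger effect at the one concentration tested and lower numbers for a weaker effect. Compound 1 `N#CC1=C(NC(=S)Nc2ccccc2)N(c2ccc(S(N)(=O)=O)cc2)C2=C(C(=O)CCC2)C1c1ccc(Cl)cc1Cl` gives 55%. Compound 2 `N#CC1=C(NC(=S)Nc2ccc(Cl)cc2)N(c2ccc(S(N)(=O)=O)cc2)C2=C(C(=O)CCC2)C1c1ccc(Cl)cc1Cl` gives 100%, while compound 3 `N#CC1=C(NC(N)=O)N(c2ccc(S(N)(=O)=O)cc2)C2=C(C(=O)CCC2)C1c1ccc(Cl)cc1Cl` gives 40%, the lowest of the three. The step of a number 15 percentage points lower from compound 1 to compound 3 (beyond the scatter) and the step of a number 60 percentage points lower from compound 2 to compound 3 (beyond the scatter) both show a fall when the larger ring-bearing group on the amine nitrogen gives way to the smaller group. Compound 4 `N#CC1=C(NC(=O)CCC(=O)O)N(c2ccc(S(N)(=O)=O)cc2)C2=C(C(=O)CCC2)C1c1ccc(Cl)cc1Cl` differs from compound 3 by 2-carboxyethyl in place of amino on a carbonyl carbon. This adds chain atoms without any ring, so the measured steps bear only loosely on it. Only a modest change is expected, a number 5 percentage points higher from compound 3 to compound 4 (within the scatter), and compound 4 is estimated at 45%, within 25% to 70%.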

Compound 4, a percentage reported as activity, at one concentration (the size of the read-out at that concentration, not a potency): 50%
For compound 4 the middle estimate is 5 percentage points below the measured one, and the stated range covers the measured number.
By their numbers in this assay, from the lowest: compounds 3, 4 and 1 (each within the scatter of the next, the first and the last beyond it); then compound 2.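

In this assay, 2-carboxyethyl in place of amino on this carbonyl carbon gives no clear shift (a number 10 percentage points higher from compound 3 to compound 4 (within the scatter)), so this position tolerates a ring-free chain ending in a carboxylic acid. That ring-free arm also matches the ring-bearing arm without chlorine (a number 5 percentage points lower from compound 1 to compound 4 (within the scatter)), but not the ring-bearing arm with chlorine (a number 50 percentage points lower from compound 2 to compound 4 (beyond the scatter)). Nothing measured here offers an explanation for these results. The compounds shown leave open whether the acid or the chain matters; a methyl ester, an amine at the chain end or a longer chain would separate the two.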